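The source may report more compounds than this note shows. Statements on the series, on what has been measured and on what is new or still open speak of the compounds shown alone.

Values measured in a functional assay on the whole organism with Mus musculus as the target; a higher number here means that more compound is needed for the effect, a lower number that less compound is needed:
- Compound 1 `C[C@@H](NCc1ccc(OCc2ccc(F)cc2)cc1)C(N)=O`: 132 mg/kg
- Compound 2 `C[C@@H](NCc1ccc(OCc2ccccn2)cc1)C(N)=O`: 172 mg/kg

Compound 2, at 172 mg/kg, stands within the usual scatter of compound 1, so these two numbers do not rank one above the other. The next structure, compound 3 `C[C@@H](NCc1ccc(OCc2ccco2)cc1)C(N)=O`, keeps the shared core and changes a single group: furan-2-yl in place of pyridin-2-yl on a saturated chain carbon bound to an oxygen on an aromatic ring. Within the data shown here, one measured step bears on this change, the exchange of 4-fluorophenyl for pyridin-2-yl at the same place, which gave a 1.3-fold higher number from compound 1 to compound 2 (0.11 log units; within the scatter). Among the measured compounds shown here, that single step stayed within the scatter, but it is thin evidence, and no five-membered aromatic ring has been measured at this place so far. A step beyond the scatter is therefore not expected in this assay, in either direction. The estimated step is a 1.1-fold lower number from compound 2 to compound 3 (0.06 log units; within the scatter). The estimated value for compound 3 is 150 mg/kg, with an expected range from 80 mg/kg to 280 mg/kg.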

Compound 3, dose for half-maximal effect: 116 mg/kg
Compound 3: middle estimate off by 1.3-fold (0.11 log units), on the high side, and the stated range covers the measured number.
By their numbers in this assay, from the lowest: compounds 3, 1 and 2 (each within the scatter of the next).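

In this assay, the exchange of pyridin-2-yl for furan-2-yl on a saturated chain carbon bound to an oxygen on an aromatic ring gave a 1.5-fold lower number from compound 2 to compound 3 (0.17 log units; within the scatter), and the exchange of 4-fluorophenyl for furan-2-yl at the same place gave a 1.1-fold lower number from compound 1 to compound 3 (0.06 log units; within the scatter). The earlier compounds had shown only that two six-membered aromatic rings could not be told apart at this position; the five-membered ring, with oxygen as its hetero atom instead of nitrogen, now joins them, and all three compounds remain unranked in this assay. Nothing in the data available accounts for how closely these rings agree.

All three groups at this position are aromatic rings, so it remains open whether a saturated ring such as cyclohexyl or tetrahydrofuran-2-yl, or a group carrying an amine or a carboxylic acid, would stay within the scatter of these compounds. Going by these compounds, it is also open whether a second five-membered aromatic ring, such as thiophen-2-yl, would read like furan-2-yl, and whether any group at this place can produce a step beyond the scatter at all.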